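Thiophene to pyridine on the shared core of compound 2

This account rests on a few compounds, and the source may have more. Where it says the series, first, only, none or still open, it means among the compounds named here.

The series is built around a shared core carrying a hydroxyphenyl group, a chlorophenyl group and a third aromatic ring. Compound 1 `Oc1ccc(-c2cc(-c3cccc(Cl)c3)nc(-c3ccccn3)c2)cc1` in a functional assay on DU-145 cells (Homo sapiens) for cytotoxicity, read by CCK-8 assay and cell counting, with a stated time of 2 days (a lower number here means a stronger inhibitor, a higher number a weaker inhibitor), gives 35200 nM. Compound 2 `Oc1cccc(-c2cc(-c3ccc(Cl)cc3)nc(-c3cccs3)c2)c1` in this assay gives 11600 nM, the lower of the two numbers reported so far, and the gap between compound 2 and compound 1 lies beyond the usual scatter. Compound 3 `Oc1cccc(-c2cc(-c3ccncc3)nc(-c3ccccc3Cl)c2)c1` was examined, but in this assay compound 3 gives "not determined" (no result reported), so no number is available for it.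

Compound 4 `Oc1cccc(-c2cc(-c3ccc(Cl)cc3)nc(-c3ccccn3)c2)c1` differs from compound 2 in one place: pyridin-2-yl in place of thiophen-2-yl on an aromatic carbon. For the measured compounds named here, no pair of measured compounds differing only in this way is available, so the size of the step cannot be read directly from the data. Compound 1, which also carries a pyridin-2-yl, differs from compound 2 in the hydroxyphenyl and chlorophenyl groups as well, so the value of compound 1, 35200 nM, only loosely hints that the pyridin-2-yl variant may come out weaker. On this basis the step from compound 2 to compound 4 is expected to be a 1.6-fold higher number from compound 2 to compound 4 (0.19 log units; within the scatter), a modest increase at most and possibly none beyond the scatter. Compound 4 is therefore estimated at 18000 nM, with a range from 7000 nM to 45000 nM.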

Compound 4, half-maximal inhibitory concentration: 8090 nM
Compound 4: middle estimate off by 2.2-fold (0.35 log units), on the high side, within the range that was stated.
By their numbers in this assay, from the lowest: compounds 4 and 2 (each within the scatter of the next); then compound 1.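

With compound 4, the shared core now has a first pair differing in one place, and in this assay the change of thiophen-2-yl to pyridin-2-yl gives a 1.4-fold lower number from compound 2 to compound 4 (0.16 log units; within the scatter) and so separates the two rings by no more than repeated measurements would. At this position, on an aromatic carbon next to the ring nitrogen, a five-membered aromatic ring with 1 hetero atom and a six-membered aromatic ring with 1 hetero atom therefore cannot be told apart in this cytotoxicity read-out, with the 3-hydroxyphenyl and 4-chlorophenyl groups held constant. No measurement is at hand that could explain this result or link it to any property of either ring.

What the compounds shown leave open is whether a group of another kind at this position, such as an amine, a carboxylic acid or a longer alkyl chain, would take the number beyond the scatter. They also leave open whether the match between thiophen-2-yl and pyridin-2-yl would hold with the hydroxyl or the chlorine placed elsewhere on their phenyl rings.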